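Hydroxyethoxy in Place of Hydroxyethyl on the Shared Core

The source may report more compounds than this note shows. Statements on the series, on what has been measured and on what is new or still open speak of the compounds shown alone.

Compound 1 `CC(=O)OCCOn1cnc2c(S)nc(F)nc21` gives 37000 nM in a functional assay on CCRF-CEM cells (Homo sapiens) for inhibition; on this read-out higher numbers stand for weaker inhibition and lower numbers for stronger inhibition.
Compound 2 `CC(O)n1cnc2c(S)nc(F)nc21` reaches only > 500000 nM in this assay.

For compound 2 the entry is a limit of the assay, not a measured number; it is the limit of > 500000 nM in this assay, at which 1 of the 2 values shown sits, so compound 2 shows no inhibition that this assay could put a figure on. For the measured compounds named here, compound 1 carries a different chain on the same aromatic nitrogen of the shared core, and its figure is the only real number in the set.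

Compound 3 `OCCOn1cnc2c(S)nc(F)nc21` has not yet been measured. It differs from compound 2 by 2-hydroxyethoxy in place of 1-hydroxyethyl on an aromatic nitrogen, in words: 2-hydroxyethoxy in place of 1-hydroxyethyl on an aromatic nitrogen. Going by the values given here, no pair of measured compounds that differ in one place is available, so the size of this step can only be guessed. In this assay a step toward stronger inhibition, beyond the scatter, is expected, guided by compound 1 giving 37000 nM with a two-carbon chain attached through oxygen. Compound 3 is therefore expected to give 60000 nM, within 10000 nM to 400000 nM. That expectation amounts to an at least 8.3-fold lower number from compound 2 to compound 3 (0.92 log units; beyond the scatter).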

Compound 3, half-maximal inhibitory concentration: 117000 nM
Compound 3: middle estimate off by 2.0-fold (0.29 log units), on the low side; low and high end bracket the measured number.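

On the aromatic nitrogen of the shared core, 2-hydroxyethoxy in place of 1-hydroxyethyl gives an at least 4.2-fold lower number from compound 2 to compound 3 (0.63 log units; beyond the scatter) in this assay, which shows that the read-out at this position responds to the chain it carries. The entry for compound 2 is a limit and not a number, so this step has a minimum size but no exact one: the limit of > 500000 nM in this assay, at which 1 of the 3 values shown sits.

The end of the chain counts as well: hydrogen in place of acetyl on an oxygen on a saturated carbon gives a 3.2-fold higher number from compound 1 to compound 3 (0.50 log units; beyond the scatter) in this assay, so the free hydroxyl of compound 3 goes with weaker inhibition than the acetyl-capped chain of compound 1.

The change from 1-hydroxyethyl to 2-hydroxyethoxy replaces the whole chain at once, and the compounds shown cannot separate the added oxygen from the other differences between the two chains. Also open, on these data alone, is whether a longer chain, or an amine in place of the hydroxyl at the end of the chain, would move the number further in either direction.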